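Chain change on the carbonyl carbon: compound 2 to compound 3

The source may report more compounds than this note shows. Statements on the series, on what has been measured and on what is new or still open speak of the compounds shown alone.

Within the data shown here, in a functional assay on MGC-803 cells (Homo sapiens) for inhibition, read by MTT assay, with a stated time of 48 h (a lower number here means a stronger inhibitor, a higher number a weaker inhibitor), compound 1 (`CCCCC(=O)N(Cc1ccc(OC)c(O)c1)c1cc(OC)c(OC)c(OC)c1`) reads 66 nM while compound 2 (`C/C=C/C(=O)N(Cc1ccc(OC)c(O)c1)c1cc(OC)c(OC)c(OC)c1`) reads 27 nM as the lower of the two numbers so far. Compound 3 (`COc1ccc(CN(C(=O)CCCCCl)c2cc(OC)c(OC)c(OC)c2)cc1O`) differs from compound 2 on a carbonyl carbon, with 4-chlorobutyl in place of prop-1-en-1-yl (4-chlorobutyl in place of prop-1-en-1-yl on a carbonyl carbon). Among the measured compounds shown here, the one measured step at this place, butyl to prop-1-en-1-yl, is a 2.4-fold lower number from compound 1 to compound 2 (0.39 log units; beyond the scatter) and it is modest. The nearest measured case is the butyl of compound 1 at 66 nM and, like that butyl, 4-chlorobutyl has no double bond, so a higher number of similar size is expected in this assay although no chlorine-bearing chain has been measured. The expected step is a 2.6-fold higher number from compound 2 to compound 3 (0.41 log units; beyond the scatter) as estimated here. Compound 3 is estimated at 70 nM with an expected range from 25 nM to 200 nM in this series.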

Compound 3, half-maximal inhibitory concentration: 540 nM
Compound 3: middle estimate off by 7.7-fold (0.89 log units), on the low side; the whole stated range lies below it.
By their numbers in this assay, from the lowest: compound 2; then compound 1; then compound 3.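

In this assay, among these compounds, this position proves far less forgiving than the one earlier step suggested: the change to 4-chlorobutyl gives a 20-fold higher number from compound 2 to compound 3 (1.30 log units; beyond the scatter) and is a large step. The absence of the double bond does not account for the whole loss, since chloro in place of hydrogen on the saturated chain, four bonds along the chain from a carbonyl carbon, gives an 8.2-fold higher number from compound 1 to compound 3 (0.91 log units; beyond the scatter) and leaves compound 3 the weakest of the three. Nothing available here gives a reason for this loss.

From the compounds shown here alone, whether the loss is specific to chloro stays open; fluoro, hydroxyl or an amine on the same chain carbon would test this. Also open, going by these compounds, is whether the gain in compound 2 comes from its double bond or its shorter chain, a question a saturated propyl chain would address.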